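Extending compound 3 at its double-bonded nitrogen

The source may hold more compounds than are shown below. What is called first, only, known or untested is meant among the compounds shown, and "the series" means these compounds.

In a functional assay on MCF7 cells (Homo sapiens) for antiproliferative activity, with a stated time of 5 days (a higher number here means a weaker inhibitor, a lower number a stronger inhibitor), compound 3 (`CCCCc1ccc2[nH]c(-c3ccc(OC)cc3)c(/C=N/O)c2c1`) gives 212 nM and lies within the scatter of compound 2 (`COc1ccc(-c2[nH]c3ccc(C)cc3c2C=O)cc1`), which gives 140 nM as its value. Compound 1 (`CCCCc1ccc2[nH]c(-c3ccc(OC)cc3)c(C=O)c2c1`) stands apart with the lowest number at 22 nM and is clearly the strongest of the three. The change to compound 4 (`CCCCc1ccc2[nH]c(-c3ccc(OC)cc3)c(/C=N/NC(=O)c3ccc(Cl)cc3)c2c1`) is ((4-chlorophenyl)carbonyl)amino in place of hydroxy on a double-bonded nitrogen. The step that bears most directly on this is (a 9.6-fold higher number from compound 1 to compound 3 (0.98 log units; beyond the scatter)), where a larger group at the same spot came with a higher number. The other step (a 6.4-fold higher number from compound 1 to compound 2 (0.80 log units; beyond the scatter)) concerns the chain, which compound 4 keeps unchanged, so it says little here. Going by the values given here, no measured compound carries the entering group, so the uncertainty is wide. Among the compounds with values here, a modest move to a higher number is expected, no larger than the step from the aldehyde-bearing compound 1 to its hydroxy-bearing partner, and the estimated step is (a 3.3-fold higher number from compound 3 to compound 4 (0.52 log units; beyond the scatter)). Compound 4 is thus expected at 700 nM with 130 nM and 3500 nM as the ends of the estimated range.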

Compound 4, half-maximal inhibitory concentration: 220 nM
Beside the measured number, compound 4's estimate is 3.2-fold (0.50 log units) above it; the range from low to high includes it.
By their numbers in this assay, from the lowest: compound 1; then compounds 2, 3 and 4 (each within the scatter of the next).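

Replacing hydroxy with ((4-chlorophenyl)carbonyl)amino on a double-bonded nitrogen gives, in this assay, a 1.0-fold higher number from compound 3 to compound 4 (0.02 log units; within the scatter). The earlier compounds shown here offered no comparison at this nitrogen; this pair shows that a much larger group, carrying a six-membered aromatic ring of carbon only, can stand there in place of hydroxy with no change beyond the scatter in this antiproliferative read-out. Nothing shown accounts for why the number holds with so large a change.

Still open, as far as these compounds go, is whether the chlorine contributes anything, or whether a plain phenylcarbonylamino group at the same nitrogen would read the same. From the compounds shown here alone, it is equally open how a simple amine or a methoxy group would behave there, and whether a still longer group on this nitrogen would move the number.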